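Chlorobenzyl swap on a shared core in rat artery

The source may report more compounds than this note shows. Statements on the series, on what has been measured and on what is new or still open speak of the compounds shown alone.

The measured compounds, in a functional assay on the whole organism (artery, strain albino) with Rattus norvegicus as the target, with a stated time of 240 min, at a dose of 10 mg/kg by the oral route; a higher number here means more inhibition at the dose given (going by the name of the read-out), a lower number less inhibition:

Compound 1, `CC1=C(C(=O)Nc2ccc(F)cc2)C(c2ccc([N+](=O)[O-])cc2)N=C(SCc2ccccc2Cl)N1`, gives 15.9%.
Compound 2, `CC1=C(C(=O)Nc2ccc(F)cc2)C(c2ccc([N+](=O)[O-])cc2)N=C(SCc2cccc(Cl)c2)N1`, gives 15.9%.
Compound 3, `CC1=C(C(=O)Nc2ccc(Br)cc2)C(c2ccc(Cl)cc2Cl)N=C(SCc2ccccc2Cl)N1`, gives 28.7%.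

Compound 1 and compound 2 share one core and differ in a single place: 3-chlorophenyl in place of 2-chlorophenyl on a saturated chain carbon bound to a sulfur. That exchange produced no change at the digits printed from compound 1 to compound 2 (within the scatter), so the two numbers are to be read as the same result. Compound 3 rests on a different core; how the core of compound 3 differs from the core of compound 1 is not broken down here. Compound 3 gives the highest number of the three, and its gaps to compound 1 and to compound 2 both lie beyond the scatter.

Compound 4, `CC1=C(C(=O)Nc2ccc(Br)cc2)C(c2ccc(Cl)cc2Cl)N=C(SCc2cccc(Cl)c2)N1`, has not yet been measured. It differs from compound 3 by 3-chlorophenyl in place of 2-chlorophenyl on a saturated chain carbon bound to a sulfur, the same change, at the same place, that separates compound 1 from compound 2. Since that earlier exchange gave no change at the digits printed from compound 1 to compound 2 (within the scatter), the step from compound 3 to compound 4 is expected to be about as small: a number 1.7 percentage points lower from compound 3 to compound 4 (within the scatter). Within the data shown here, compound 4 is therefore estimated at 27% in this assay, with a likely range from 15% to 40%, the width reflecting that only one earlier instance of this change is available.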

Compound 4, a percentage reported as inhibition, in the whole organism at one dose (the size of the read-out at that dose, not a potency): 15.9%
For compound 4 the middle estimate is 11.1 percentage points above the measured one, within the range that was stated.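

In this assay, the change from 2-chlorobenzyl to 3-chlorobenzyl gave no change at the digits printed from compound 1 to compound 2 (within the scatter) on one core and a number 12.8 percentage points lower from compound 3 to compound 4 (beyond the scatter) on the other. The second step on its own lies beyond the usual scatter, yet the two steps cannot be told apart when set side by side: the same change on two cores in this assay, no change at the digits printed (within the scatter) from compound 1 to compound 2 and a number 12.8 percentage points lower (beyond the scatter) from compound 3 to compound 4, 12.8 percentage points apart, within the scatter of two such steps. The series therefore does not show that the change carries over unaltered from one core to another, nor does it show that the outcome depends on the core, since one pair on each core gives two observations and no rule.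

Only 2-chlorobenzyl and 3-chlorobenzyl sit on the sulfur in the compounds shown, so it remains open how an unsubstituted benzyl group, a methyl group or a longer alkyl chain at that place would behave in this assay. Also open, going by these compounds, is what the same chlorobenzyl exchange would do on a third core.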